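Allyl in place of 3-bromobenzyl on a triazolopyrimidine thioether

The source may hold more compounds than are shown below. What is called first, only, known or untested is meant among the compounds shown, and "the series" means these compounds.

Three compounds share one core and were measured in a functional assay on MGC-803 cells (Homo sapiens) for inhibition, read by MTT assay, with a stated time of 72 h; on this read-out higher numbers stand for weaker inhibition and lower numbers for stronger inhibition. Compound 1 `Cc1cc(Nc2ccn(Cc3cccc4ccccc34)n2)n2nc(SCc3ccc(Br)cc3)nc2n1` gives 3240 nM. Compound 2 `Cc1cc(Nc2cc(-c3ccccc3)[nH]n2)n2nc(SCc3cccc(Br)c3)nc2n1` gives 4820 nM. Compound 3 `Cc1nc2nc(SCc3ccc(Cl)cc3)nn2c(Nc2cc(-c3ccccc3)[nH]n2)c1C` gives 9050 nM. The number for compound 2 lies within the scatter of both compound 1 and compound 3, so the three cannot be told apart on these data. Compound 4 `C=CCSc1nc2nc(C)cc(Nc3cc(-c4ccccc4)[nH]n3)n2n1` has not yet been measured in this assay. It differs from compound 2 in one place: vinyl in place of 3-bromophenyl on a saturated chain carbon bound to a sulfur. Going by the values given here, no measured pair shows this change, so its effect is open. Among the compounds with values here, the account expects a weakening step, somewhat beyond the scatter, since the ring that leaves is the only aromatic group on that side in the measured compounds. For compound 4 the expected step is a 2.5-fold higher number from compound 2 to compound 4 (0.40 log units; beyond the scatter), and the estimate is 12000 nM, within a range from 4000 nM to 40000 nM.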

Compound 4, half-maximal inhibitory concentration: 17200 nM
For compound 4 the middle estimate is 1.4-fold (0.16 log units) below the measured one; the range from low to high includes it.
By their numbers in this assay, from the lowest: compounds 1, 2, 3 and 4 (each within the scatter of the next, the first and the last beyond it).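

In this assay, allyl in place of 3-bromobenzyl on the sulfur gives a 3.6-fold higher number from compound 2 to compound 4 (0.55 log units; beyond the scatter), a modest step. Going by these compounds alone, it is the first single change read at this position, and it shows that the group on the sulfur matters to this read-out. Nothing measured here explains the step.

The compounds shown leave open whether the step follows the loss of the ring, the bromine or the chain length. A plain benzyl, a propyl or a longer chain on the sulfur would bear on that question.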